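Triazole substituent swaps in a nucleoside series: cytotoxicity notes

This account rests on a few compounds, and the source may have more. Where it says the series, first, only, none or still open, it means among the compounds named here.

Three measured compounds share one core and differ only in the group on the triazole. Compound 1 `CCS[C@@H]1[C@H](SCC)[C@@H](Cn2cc(-c3ccc(OC)cc3)nn2)O[C@H]1n1ccc(=O)[nH]c1=O` carries 4-methoxyphenyl, compound 2 `CCS[C@@H]1[C@H](SCC)[C@@H](Cn2cc(-c3ccccc3C(F)(F)F)nn2)O[C@H]1n1ccc(=O)[nH]c1=O` carries 2-(trifluoromethyl)phenyl, and compound 3 `CCS[C@@H]1[C@H](SCC)[C@@H](Cn2cc(-c3cccc(C)c3)nn2)O[C@H]1n1ccc(=O)[nH]c1=O` carries 3-methylphenyl. In a functional assay on A549 cells (Homo sapiens) for cytotoxicity, read by MTT assay, with a stated time of 72 h (a higher number here means that more compound is needed for the effect, a lower number that less compound is needed), compound 1 gives 16800 nM, compound 2 gives 19400 nM, and compound 3 gives 12200 nM. Compound 2 holds the highest of the three numbers, but the steps of a 1.2-fold higher number from compound 1 to compound 2 (0.06 log units; within the scatter) and a 1.6-fold lower number from compound 2 to compound 3 (0.20 log units; within the scatter) both fall within the scatter, as does a 1.4-fold lower number from compound 1 to compound 3 (0.14 log units; within the scatter), so the three aryl groups are not separable on these data.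

Compound 4 `CCS[C@@H]1[C@H](SCC)[C@@H](Cn2cc(COC(C)=O)nn2)O[C@H]1n1ccc(=O)[nH]c1=O` has not been measured. Its change from compound 2 is acetoxymethyl in place of 2-(trifluoromethyl)phenyl on an aromatic carbon. Going by the values given here, every measured step exchanges one aryl group for another aryl group; none replaces the ring with a chain, so no measured step bears directly on this change. The aryl swaps are all within the scatter, and with nothing pointing to a larger move, the expected step of a 1.0-fold higher number from compound 2 to compound 4 (0.01 log units; within the scatter) is none beyond the scatter in this assay. Compound 4 is therefore estimated at 20000 nM, with a range from 8000 nM to 50000 nM, and a weaker outcome remains possible.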

Compound 4, half-maximal effective concentration: >= 100000 nM
Compound 4 was reported as a limit; the forecaster's own chance of this, stated with the estimate: 10%; at least 5.0-fold (0.69 log units) between middle value and limit.
By their numbers in this assay, from the lowest: compounds 3, 1 and 2 (each within the scatter of the next). At a limit, above all of these: compound 4.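

In this assay, the three aryl groups on the triazole could not be told apart, but this position does respond once the ring is given up for the acetoxymethyl chain: an at least 5.1-fold higher number from compound 2 to compound 4 (0.71 log units; beyond the scatter), an at least 8.1-fold higher number from compound 3 to compound 4 (0.91 log units; beyond the scatter) and an at least 5.9-fold higher number from compound 1 to compound 4 (0.77 log units; beyond the scatter). All three steps lie beyond the scatter, whichever aryl group is taken as the starting point, so the earlier flat picture held only among the aryl compounds 1, 2 and 3 and does not extend to this chain. Compound 4 is reported only as a limit and not as a number: the limit of >= 100000 nM in this assay, at which 1 of the 4 values shown sits.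

The change removes an aromatic ring and brings in an ester in a single move, so the compounds shown cannot say which of the two carries the step, or how far compound 4 lies past its limit. A hydroxymethyl group or a plain hexyl chain on the same triazole carbon would separate the ester from the loss of the ring, and a benzyl group would show whether a ring set one carbon away from the triazole behaves like the directly attached aryl groups.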